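The source may hold more compounds than are shown below. What is called first, only, known or untested is meant among the compounds shown, and "the series" means these compounds.

Compound 1 `CC(Oc1ccccc1C=O)C1=NCCN1` and compound 2 `Cc1cccc(C)c1OC(C)C1=NCCN1` share a core and were both tested in an assay on CHO cells with Alpha-2C adrenergic receptor (Homo sapiens) as the target; a lower number here means a smaller maximal response, a higher number a larger maximal response. In this assay, within the data shown here, compound 1 gives 0.6, the lower of the two numbers known here, while compound 2 reaches 0.82, a gap that lies beyond the usual scatter of this kind of measurement. The two compounds differ in more than one place, so their two numbers are all that can be said of them together.

Compound 3 `CC(Oc1ccccc1Br)C1=NCCN1` is the next compound and has not yet been measured. It differs from compound 1 in one place: bromo in place of formyl on an aromatic carbon. For this assay a step upward from compound 1 is expected, of a size beyond the scatter, and it is written as a number 0.15 higher from compound 1 to compound 3 (beyond the scatter). Compound 3 is therefore estimated to give 0.75 in this assay, with a plausible range from 0.55 to 0.95.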

Compound 3, intrinsic activity: the largest response reached, as a fraction of the reference agonist's: 0.87
Compound 3: middle estimate off by 0.12, on the low side, and the stated range covers the measured number.
By their numbers in this assay, from the lowest: compound 1; then compounds 2 and 3 (each within the scatter of the next).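

In this assay the change from formyl to bromo on this aromatic carbon gives a number 0.27 higher from compound 1 to compound 3 (beyond the scatter) and so shows that the maximal response depends on which group sits at this position. The group that leaves has two heavy atoms, a double bond and a hydrogen-bond acceptor, whereas the bromo group that enters is a single atom with no acceptor, and this one swap cannot separate those differences. No measurement given here explains why the response changes.

Open, going by these compounds, is how other groups on this same aromatic carbon would compare, such as a methoxy group, an amine or a carboxylic acid. Also open, on these data alone, is whether the swap from formyl to bromo would give a step of similar size with a different group elsewhere on the core.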